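Working notes: ring change from compound 3 to compound 4

The compounds below may be only part of what the source reports. "The series", "measured", "known", "first", "only" and "open" are said of these compounds alone.

Measured so far in a functional assay on K562 cells (Homo sapiens) for antiproliferative activity, with a stated time of 72 h (on this read-out lower numbers stand for stronger inhibition and higher numbers for weaker inhibition), with the values below:
- compound 1 `OC[C@H]1O[C@@H](n2cnc3c(NCc4ccc(Cl)cc4)ncnc32)[C@H](O)[C@@H]1O` gives 218000 nM as a number
- compound 2 `Cc1ccc(CNc2ncnc3c2ncn3[C@@H]2O[C@H](CO)[C@@H](O)[C@H]2O)cc1` gives > 166000 nM as a limit
- compound 3 `OC[C@H]1O[C@@H](n2cnc3c(NCc4c(F)ccc(F)c4F)ncnc32)[C@H](O)[C@@H]1O` gives > 166000 nM as a limit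

Compound 3 stands only at a limit, > 166000 nM and no number. The series as a whole offers the limit of > 166000 nM in this assay, at which 2 of the 3 values shown sit, and one readable value. Compound 4 `OC[C@H]1O[C@@H](n2cnc3c(NCc4ccc(F)cc4Cl)ncnc32)[C@H](O)[C@@H]1O` brings 2-chloro-4-fluorophenyl in place of 2,3,6-trifluorophenyl on a saturated chain carbon bound to a nitrogen on an aromatic ring, counted as 2-chloro-4-fluorophenyl in place of 2,3,6-trifluorophenyl on a saturated chain carbon bound to a nitrogen on an aromatic ring in full. Going by the values given here, two measured steps touch this same place, a step that the limit leaves unreadable from compound 1 to compound 3 and a step that the two limits leave unreadable from compound 2 to compound 3 and neither yields a size. Compound 1 at 218000 nM is therefore the only numerical anchor for the expectation. The expected step is a step that the limit leaves unreadable from compound 3 to compound 4 and no direction beyond the scatter is expected. Compound 4 is estimated at 200000 nM within 90000 nM to 400000 nM in this assay and may well report only a limit.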

Compound 4, half-maximal inhibitory concentration: 15600 nM
Compound 4: middle estimate off by 13-fold (1.11 log units), on the high side; measured number below the stated range.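

Until now the steps among compound 1, compound 2 and compound 3 could not be read, so this place gave no size; in this assay the aryl group on a saturated chain carbon bound to a nitrogen on an aromatic ring now proves able to shift the read-out, with 2-chloro-4-fluorophenyl giving an at least 10-fold lower number from compound 3 to compound 4 (1.02 log units; beyond the scatter), an at least 10-fold lower number from compound 2 to compound 4 (1.02 log units; beyond the scatter) and a 14-fold lower number from compound 1 to compound 4 (1.15 log units; beyond the scatter). Only the last of these runs between two numbers, as the other two start from limits: the limit of > 166000 nM in this assay, at which 2 of the 4 values shown sit.
A chlorine on the phenyl is not enough for this level, since compound 1 carries one as 4-chlorophenyl.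

No compound shown separates the contribution of the fluorine from that of the chlorine in 2-chloro-4-fluorophenyl. Going by these compounds, whether an amine on the phenyl or a longer chain at the saturated chain carbon would take the series past compound 4 at 15600 nM also stays open.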